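The compounds below may be only part of what the source reports. "The series", "measured", "known", "first", "only" and "open" are said of these compounds alone.

Measured in a functional assay on OVCAR-8 cells (Homo sapiens) for cytotoxicity, read by sulforhodamine B assay, with a stated time of 48 h, tested at 0.1 uM; on this read-out lower numbers stand for a stronger effect and higher numbers for a weaker effect at the one concentration tested:
- compound 1 `COc1ccc(-c2cc(/C=C/C(=O)c3ccc(N)cc3)[nH]n2)cc1`: 100%
- compound 2 `COc1cc(-c2cc(/C=C/C(=O)c3ccc(N)cc3)[nH]n2)cc(OC)c1OC`: 98%
- compound 3 `COc1cc(-c2cc(/C=C/C(=O)c3ccc(Cl)c(Cl)c3)[nH]n2)cc(OC)c1OC`: 97%

Compound 2 stands second highest of the three numbers. Its nearest neighbour is compound 3, whose value sits a number 1 percentage points lower from compound 2 to compound 3 (within the scatter), a change at the carbonyl end of the molecule that lies within the scatter. Compound 1, which differs from compound 2 by two methoxy groups on the same six-membered aromatic ring, shows a value only a little higher, and the gap between the two is also within the scatter. Within the data shown here, no measured step in this assay therefore shows any movement beyond scatter.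

Compound 4 `COc1ccc(-c2cc(/C=C/C(=O)c3ccc(N)cc3)[nH]n2)cc1OC` is not yet measured. It differs from compound 2 by hydrogen in place of methoxy on an aromatic carbon. Among the measured compounds shown here, no measured step concerns the methoxy pattern of that ring directly; the only counted step, from compound 2 to compound 3, changes a different part of the molecule and stayed within the scatter, and compounds 1 and 2, which do differ in methoxy count on that ring, give values within the scatter of each other. Nothing in the series points to a step beyond the scatter for this change.

For compound 4 in this assay a value of 98% is expected, between 91% and 104%, which would mean an estimated step of no change at the digits printed from compound 2 to compound 4 (within the scatter).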

Compound 4, a percentage reported as activity, at one concentration (the size of the read-out at that concentration, not a potency): 99%
Compound 4: middle estimate off by 1 percentage points, on the low side; low and high end bracket the measured number.
By their numbers in this assay, from the lowest: compounds 3, 2, 4 and 1 (each within the scatter of the next).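

Among these compounds, compound 4 gives the first direct reading at this position in this assay: with hydrogen in place of methoxy on an aromatic carbon, ortho to a methoxy group and meta to a large group, the result is a number 1 percentage points higher from compound 2 to compound 4 (within the scatter). A second single-place comparison, with methoxy in place of hydrogen on an aromatic carbon, gives a number 1 percentage points lower from compound 1 to compound 4 (within the scatter), so compound 4 is separated from neither neighbour and the number of methoxy groups on this ring, across compounds 1, 4 and 2, has no readable effect on the read-out at the one concentration tested. No supporting measurement offers an explanation for this outcome.

Hydrogen and methoxy are the only groups compared at this position, so a hydroxy group, a fluorine atom or a longer ethoxy chain there remains an open case. Also open, as far as these compounds go, is whether compounds 1, 2, 3 and 4 would separate at another concentration, and whether the 3,4-dichlorophenyl group seen in compound 3 would behave the same way alongside the methoxy patterns of compounds 1 and 4.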